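Compound 3 to compound 4: carbamoyl replaces the side chain

This account rests on a few compounds, and the source may have more. Where it says the series, first, only, none or still open, it means among the compounds named here.

Measured in a functional assay with Oryctolagus cuniculus as the target; on this read-out higher numbers stand for weaker inhibition and lower numbers for stronger inhibition:
- compound 1 `COc1ccc(-c2nc(/N=C(\N)[N+]3(C)CCCCC3)sc2-c2ccc(OC)cc2)cc1`: > 1000 nM, a limit
- compound 2 `COc1ccc(-c2nc(/N=C(\N)n3ccnc3)sc2-c2ccc(OC)cc2)cc1`: > 100 nM, a limit
- compound 3 `COc1ccc(-c2nc(CNC(=O)CSC)sc2-c2ccc(OC)cc2)cc1`: < 100 nM, a limit

Compound 3 is known only through its limit of < 100 nM. Compound 4 `COc1ccc(-c2nc(C(N)=O)sc2-c2ccc(OC)cc2)cc1` differs from compound 3 in this way: carbamoyl in place of ((((methylsulfanyl)methyl)carbonyl)amino)methyl on an aromatic carbon. The group on this aromatic carbon has moved the read-out beyond the scatter in an at least 10-fold lower number from compound 1 to compound 3 (1.00 log units; beyond the scatter), while a number no higher from compound 2 to compound 3 (the limit leaves the size open) leaves the size open. For the measured compounds named here, no measured step shortens the chain of compound 3, so the evidence is thin and the direction is tentative. A modest step is expected, an at least 2.0-fold higher number from compound 3 to compound 4 (0.30 log units; that floor lies within the scatter), towards a higher number in this assay. For compound 4 the estimated value is 200 nM, with an expected range of 30 nM to 1500 nM.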

Compound 4, half-maximal inhibitory concentration: > 1000 nM
Compound 4 ended at the assay's limit; the forecaster's own chance of this, stated with the estimate: 60%; at least 5.0-fold (0.69 log units) between middle value and limit.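

In this assay, carbamoyl in place of ((((methylsulfanyl)methyl)carbonyl)amino)methyl on this aromatic carbon gives an at least 10-fold higher number from compound 3 to compound 4 (1.00 log units; beyond the scatter), the first readable step upward at this position. The entering group has the same count of one hydrogen-bond donor, so that count alone does not hold the read-out at the level of compound 3. The value of compound 4 is a limit: the limit of > 1000 nM in this assay, at which 2 of the 4 values shown sit.

The steps from compound 1 and compound 2 to compound 4 cannot be read. As far as these compounds go, whether an aminomethyl or an acetamidomethyl group at this position would give a low number stays open.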